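A few compounds are considered here, and "the series" means these few. Any claim that something is new, unique, unknown or untested is made for them only; others in the source may bear on it.

Working notes on the series.

Compound 1 `COc1ccc(-c2nc3cc(/C(C)=N/NC(N)=O)ccc3[nH]2)cc1` carries a carbamoyl on the amine nitrogen and a single methoxy on the six-membered ring. In an ADME assay on MDBK cells (Bos taurus) for cytotoxicity, read by MTT assay, with a stated time of 96 h (on this read-out lower numbers stand for higher toxicity in this test and higher numbers for lower toxicity in this test), compound 1 gives 25000 nM. Compound 2 `COc1ccc(-c2nc3cc(/C(C)=N/NC(N)=O)ccc3[nH]2)c(OC)c1` adds a second methoxy; the change is methoxy in place of hydrogen on an aromatic carbon. In this assay compound 2 gives > 100000 nM, which is a limit of the test and not a number. The step of an at least 4.0-fold higher number from compound 1 to compound 2 (0.60 log units; beyond the scatter) is therefore bounded only on one side, and the line the limit of > 100000 nM in this assay, at which 1 of the 3 values shown sits, marks where the measurement stops. Compound 3 `COc1ccc(-c2nc3cc(/C(C)=N/NC(N)=S)ccc3[nH]2)cc1` differs from compound 1 in the core: a group of 3 heavy atoms (1 carbon, 1 nitrogen, 1 sulfur; no ring) in place of a group of 3 heavy atoms (1 carbon, 1 nitrogen, 1 oxygen; no ring), on an amine nitrogen. In this assay compound 3 gives 13000 nM, and the step of a 1.9-fold lower number from compound 1 to compound 3 (0.28 log units; within the scatter) leaves compound 1 and compound 3 indistinguishable within the scatter.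

Compound 4 `COc1ccc(-c2nc3cc(/C(C)=N/NC(N)=S)ccc3[nH]2)c(OC)c1` has not been measured in this assay. It differs from compound 3 by methoxy in place of hydrogen on an aromatic carbon, the same change that separates compound 1 from compound 2. That earlier change gave an at least 4.0-fold higher number from compound 1 to compound 2 (0.60 log units; beyond the scatter), and the sulfur core of compound 3 behaved like the oxygen core of compound 1 in a 1.9-fold lower number from compound 1 to compound 3 (0.28 log units; within the scatter). Among the measured compounds shown here, on that basis the step of a 6.2-fold higher number from compound 3 to compound 4 (0.79 log units; beyond the scatter) is expected to be of the same kind and at least as large, though the one precedent is a limit, so its true size is unknown. Compound 4 is estimated at 80000 nM, with a range from 30000 nM to 250000 nM, and a fair chance that only a limit is reported.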

Compound 4, half-maximal cytotoxic concentration: > 100000 nM
Compound 4: only a limit was reported; the forecaster's own chance of this, stated with the estimate: 50%; middle value at least 1.2-fold (0.09 log units) from the limit.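

Methoxy in place of hydrogen on an aromatic carbon, ortho to a large group, moves the read-out in this assay the same way on both cores, toward lower toxicity in this test, and the new step is an at least 7.6-fold higher number from compound 3 to compound 4 (0.88 log units; beyond the scatter), so the direction of the change carries from one core to the other: the same change on two cores in this assay, an at least 4.0-fold higher number (0.60 log units; beyond the scatter) from compound 1 to compound 2 and an at least 7.6-fold higher number (0.88 log units; beyond the scatter) from compound 3 to compound 4; the limit leaves it open whether they differ

What this does not show is the size of the change on either core, since compound 2 and compound 4 both end at a limit of the test and not at a number, so neither core can be said to respond more strongly, and the step between compound 2 and compound 4 cannot be read: the limit of > 100000 nM in this assay, at which 2 of the 4 values shown sit.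

The carry-over rests on a single pair of cores and a single ring position, which makes it one observation and not a rule for the series.

Open, from the compounds shown here alone, is whether the same shift would follow from a different group at that place, such as a hydroxyl, a fluorine atom or a longer alkoxy chain. Also open, going by these compounds, is how an amine or a carboxylic acid in place of the carbamoyl on the amine nitrogen would read in this assay.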